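A few compounds are considered here, and "the series" means these few. Any claim that something is new, unique, unknown or untested is made for them only; others in the source may bear on it.

Of the compounds shown here, three built on one shared core have been measured in a functional assay on A549 cells (Homo sapiens) for cytotoxicity, read by MTT assay, with a stated time of 72 h; a higher number here means a weaker inhibitor, a lower number a stronger inhibitor. Compound 1, `COc1ccc2c(c1)[n+]([O-])nc(NCOC(C)c1ccccc1)[n+]2[O-]`, gives 3130 nM in this assay. Compound 2, `[O-][n+]1nc(NCOC2CCCCC2)[n+]([O-])c2ccccc21`, gives 5180 nM. Compound 3, `[O-][n+]1nc(NCOCc2ccc(C(F)(F)F)cc2)[n+]([O-])c2ccccc21`, gives 8420 nM. Among these three numbers compound 2 stands second highest: its nearest neighbour is compound 3, separated by a gap within the scatter, and its furthest is compound 1, also separated by a gap within the scatter. Going by the values given here, no pair of measured compounds differs in a single place, so the three values show only that they lie close together, with none clearly apart from the others.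

Compound 4, `CCCOCNc1n[n+]([O-])c2ccccc2[n+]1[O-]`, has not yet been measured. It differs from compound 2 in one place: propyl in place of cyclohexyl on an oxygen on a saturated carbon. Among the compounds with values here, no measured pair shows a change of this kind, so the expectation rests on how tightly the three known values cluster in this assay. A step of a 1.2-fold higher number from compound 2 to compound 4 (0.06 log units; within the scatter) is expected, none beyond the scatter in either direction. Compound 4 is therefore estimated at 6000 nM in this assay, within a range from 2500 nM to 15000 nM.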

Compound 4, half-maximal inhibitory concentration: 7460 nM
The estimate for compound 4 lay 1.2-fold (0.09 log units) below the measured number; the measured number falls inside the stated range.
By their numbers in this assay, from the lowest: compounds 1, 2, 4 and 3 (each within the scatter of the next, the first and the last beyond it).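

In this assay, going by these compounds alone, propyl in place of cyclohexyl on an oxygen on a saturated carbon gives the first comparison that differs in one place only: a 1.4-fold higher number from compound 2 to compound 4 (0.16 log units; within the scatter). For this one pair, the six-membered ring of carbon only can give way to a chain with no ring, and the change in the number stays within the scatter, so cyclohexyl is not needed at this place to keep the value in this range. Nothing measured here gives a reason for this outcome.

As far as these compounds go, it remains open whether a longer chain, a carboxylic acid or an amine at this place would give a step beyond the scatter. From the compounds shown here alone, it is also open whether propyl in place of cyclohexyl would behave in the same way on the core of compound 1, which carries a methoxy group.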